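Methoxy in place of hydrogen: outlook for compound 4

The source may report more compounds than this note shows. Statements on the series, on what has been measured and on what is new or still open speak of the compounds shown alone.

Measured compounds:
compound 1 `N=C(S)CCn1nc(-c2ccc(Cl)cc2)ccc1=O` — > 100 mg/kg, a limit of the assay
compound 2 `C/N=C(\S)CCn1nc(-c2ccccc2)ccc1=O` — 58.5 mg/kg
compound 3 `N=C(S)CCn1nc(-c2ccccc2)ccc1=O` — 87.3 mg/kg

In a functional assay on the whole organism (stomach) with Rattus norvegicus as the target (a higher number here means that more compound is needed for the effect, a lower number that less compound is needed), compound 3 gives 87.3 mg/kg, the highest of the two numbers; compound 2 gives 58.5 mg/kg, and a 1.5-fold higher number from compound 2 to compound 3 (0.17 log units; within the scatter). For compound 1 this assay reports only a limit (the limit of > 100 mg/kg in this assay, at which 1 of the 3 values shown sits).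

Compound 4 `COc1ccc(-c2ccc(=O)n(CCC(=N)S)n2)cc1` is not yet measured. It differs from compound 3 by methoxy in place of hydrogen on an aromatic carbon. Within the data shown here, the one measured step at this aromatic carbon is an at least 1.1-fold lower number from compound 1 to compound 3 (0.05 log units; that floor lies within the scatter), where chloro left compound 1 at the limit. Substitution at this carbon has so far brought no lower number, so for compound 4 the expected step is a 1.1-fold higher number from compound 3 to compound 4 (0.06 log units; within the scatter), none beyond the scatter or a move toward a higher number. The estimate for compound 4 is 100 mg/kg, from 55 mg/kg to 200 mg/kg.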

Compound 4, dose for half-maximal effect: > 100 mg/kg
Compound 4 ended at the assay's limit; the forecaster's own chance of this, stated with the estimate: 40%; the middle value sits exactly at the limit.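

Methoxy on this aromatic carbon, para to a large group, gives an at least 1.1-fold higher number from compound 3 to compound 4 (0.05 log units; that floor lies within the scatter) in this assay. Together with chloro, that makes two different substituents here that bring no lower number, though neither step has a known size. The step between chloro and methoxy cannot be read, and the series now leans on limits: the limit of > 100 mg/kg in this assay, at which 2 of the 4 values shown sit.

From the compounds shown here alone, how far compound 1 and compound 4 lie past that limit remains open. So does whether an amine or a carboxylic acid on this carbon would give a lower number.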